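This account rests on a few compounds, and the source may have more. Where it says the series, first, only, none or still open, it means among the compounds named here.

Compound 1 `O=C(CN1CCN(c2nnc(Cc3ccccc3)c3ccccc23)CC1)Nc1ccc(F)c(C(F)(F)F)c1` was tested in a functional assay on A549 cells (Homo sapiens) for cytotoxicity, read by MTT assay, with a stated time of 72 h (on this read-out lower numbers stand for stronger inhibition and higher numbers for weaker inhibition), where compound 1 gives 2480 nM. This is the lower of the two numbers recorded so far, though compound 2 `O=C(CN1CCN(c2nnc(Cc3ccncc3)c3ccccc23)CC1)Nc1cccc(F)c1`, which in this assay gives 4600 nM, lies within the usual scatter of it, so the two cannot be told apart. Compound 3 `O=C(CN1CCN(c2nnc(Cc3ccccc3)c3ccccc23)CC1)Nc1ccc(F)c(Cl)c1` differs from compound 1 in one place: chloro in place of trifluoromethyl on an aromatic carbon. Among the compounds with values here, no measured pair shows this change, so only a modest step from compound 1 to compound 3 in this assay is expected, one not clearly beyond the scatter, as a 1.2-fold higher number from compound 1 to compound 3 (0.08 log units; within the scatter). Compound 3 is thus estimated at 3000 nM, within 1200 nM to 8000 nM.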

Compound 3, half-maximal inhibitory concentration: "not active" (no number reported)
No number was reported for compound 3, so the estimate cannot be set against anything.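

In this assay, within the data shown here, compound 3 is recorded as not active without a number, so no step from compound 1 to compound 3 can be read. Nothing shown offers an explanation for this result. As far as these compounds go, how far chloro in place of trifluoromethyl shifts the activity remains open.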